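A few compounds are considered here, and "the series" means these few. Any claim that something is new, unique, unknown or untested is made for them only; others in the source may bear on it.

Compound 1 `CC(C)CNc1nc(N)nc2c1ncn2/C=C1/CC1(CO)CO` and compound 2 `CCCCNc1nc(N)nc2c1ncn2/C=C1/CC1(CO)CO` share one core and differ only in the chain on the nitrogen attached to it. In an ADME assay on CCRF-HSB-2 cells (Homo sapiens) for cytotoxicity, with a stated time of 7 days (a lower number here means that less compound is tolerated, a higher number that more compound is tolerated), compound 1 gives > 20000 nM, which is a limit of the assay rather than a number. In this assay compound 2 gives > 20000 nM, likewise a limit. The step that the two limits leave unreadable from compound 1 to compound 2 therefore cannot be read in size or direction, as both values sit at the limit of > 20000 nM in this assay, at which 2 of the 2 values shown sit. Compound 3 `Nc1nc(OCC(F)(F)F)c2ncn(/C=C3/CC3(CO)CO)c2n1` has not yet been measured. It differs from compound 2 by 2,2,2-trifluoroethoxy in place of butylamino on an aromatic carbon. For the measured compounds named here, no measured step touches this position, and the single measured step is itself unreadable, so nothing beyond the scatter can be predicted in either direction. Compound 3 is expected to give 20000 nM, with a range from 8000 nM to 60000 nM, because both known values rest at the limit of > 20000 nM in this assay, at which 2 of the 2 values shown sit. The expected step is a number no higher from compound 2 to compound 3 (the limit leaves the size open).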

Compound 3, half-maximal cytotoxic concentration: > 20000 nM
Compound 3 ended at the assay's limit; the forecaster's own chance of this, stated with the estimate: 75%; the middle value sits exactly at the limit.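

In this assay, for the compounds shown here, compound 1, compound 2 and compound 3 each give a limit rather than a number, so no step among them can be read: the limit of > 20000 nM in this assay, at which 3 of the 3 values shown sit. The compounds shown leave open whether isobutylamino, butylamino and 2,2,2-trifluoroethoxy on the shared core differ at all in this assay, and in which direction.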